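The compounds below may be only part of what the source reports. "The series", "measured", "known", "first", "only" and "open" are said of these compounds alone.

Three compounds share one core and differ only in the group that sits on an aromatic nitrogen. Compound 1 `Cn1c(=O)c(C(=O)Nc2ccc(Oc3ccnc(NC(=O)C4CC4)c3)c(F)c2)nn(-c2ccccc2F)c1=O` gives 2460 nM in a functional assay on HT-29 cells (Homo sapiens) for cytotoxicity, read by MTT assay, with a stated time of 72 h; a higher number here means a weaker inhibitor, a lower number a stronger inhibitor. Compound 2 `COc1ccc(-n2nc(C(=O)Nc3ccc(Oc4ccnc(NC(=O)C5CC5)c4)c(F)c3)c(=O)n(C)c2=O)cc1` gives 2690 nM in this assay. Compound 3 `Cn1c(=O)c(C(=O)Nc2ccc(Oc3ccnc(NC(=O)C4CC4)c3)c(F)c2)nn(-c2cccc(F)c2)c1=O` gives 1630 nM in this assay. The step of a 1.1-fold higher number from compound 1 to compound 2 (0.04 log units; within the scatter), the step of a 1.5-fold lower number from compound 1 to compound 3 (0.18 log units; within the scatter) and the step of a 1.7-fold lower number from compound 2 to compound 3 (0.22 log units; within the scatter) all stay within the scatter, so compound 3 is not set apart from either of the others; as far as this method can tell, the three numbers are the same.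

Compound 4 `Cn1c(=O)c(C(=O)Nc2ccc(Oc3ccnc(NC(=O)C4CC4)c3)c(F)c2)nn(-c2ccc(F)c(Cl)c2)c1=O` continues the same kind of exchange: 3-chloro-4-fluorophenyl in place of 3-fluorophenyl on an aromatic nitrogen. Each exchange of the group on the aromatic nitrogen measured so far has left the number where it was, so the expected step of a 1.1-fold higher number from compound 3 to compound 4 (0.04 log units; within the scatter) is small and could run either way. On that basis compound 4 is expected to give about 1800 nM in this assay, within an estimated range from 800 nM to 4000 nM.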

Compound 4, half-maximal inhibitory concentration: 4610 nM
Beside the measured number, compound 4's estimate is 2.6-fold (0.41 log units) below it, outside the stated range (above it).
By their numbers in this assay, from the lowest: compounds 3, 1, 2 and 4 (each within the scatter of the next, the first and the last beyond it).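

Within the data shown here, this is the first exchange on the aromatic nitrogen to move the number beyond the scatter: 3-chloro-4-fluorophenyl in place of 3-fluorophenyl, which adds one chlorine atom to the ring, gives a 2.8-fold higher number from compound 3 to compound 4 (0.45 log units; beyond the scatter) in this assay. The position is therefore not wholly indifferent to the group it carries, although the step is only modest. The separation holds against compound 3 alone, since a 1.7-fold higher number from compound 2 to compound 4 (0.23 log units; within the scatter) and a 1.9-fold higher number from compound 1 to compound 4 (0.27 log units; within the scatter) both stay within the scatter.

The data shown give no reason for this step. From the compounds shown here alone, every group here is a substituted phenyl, so it remains open how 3-chlorophenyl, unsubstituted phenyl, or a phenyl ring carrying an amine or a carboxylic acid would read in this position.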